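Chalcone series on leukaemia cells: a ring swap

This account rests on a few compounds, and the source may have more. Where it says the series, first, only, none or still open, it means among the compounds named here.

The set rests on three measured compounds. Among the measured compounds shown here, compound 1 `C=CCc1cc(C(C)=O)ccc1OCC=C(C)C` is the only one with a number: in a functional assay on CCRF-CEM cells (Homo sapiens) for cytotoxicity, with a stated time of 72 h (a higher number here means a weaker inhibitor, a lower number a stronger inhibitor), compound 1 gives 16300 nM. Compound 2 `C#CCOc1ccc(/C=C/C(=O)c2ccn(C)c2)cc1OC` reaches only a limit of this assay, and in this assay compound 2 gives > 50000 nM. Compound 3 `C#CCOc1ccc(C=O)cc1OC` likewise reaches only a limit, and in this assay compound 3 gives > 50000 nM. Compound 2 therefore stands at the ceiling of what has been observed, because of the limit of > 50000 nM in this assay, at which 2 of the 3 values shown sit.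

Compound 4 `C#CCOc1ccc(/C=C/C(=O)c2ccc(C)cc2)cc1OC` is the next compound, not yet measured. It differs from compound 2 in one place: 4-methylphenyl in place of 1-methyl-1H-pyrrol-3-yl on a carbonyl carbon

For the measured compounds named here, no step between measured compounds is known here, so the size of this change must be guessed. A move from a limit to a number would count as a step beyond the scatter, and some gain in potency is considered plausible, though the chance of a second limit remains real. Compound 4 is expected to give 20000 nM, within a range of 4000 nM to 60000 nM. The implied step an at least 2.5-fold lower number from compound 2 to compound 4 (0.39 log units; beyond the scatter) is thus estimated as a modest gain.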

Compound 4, half-maximal inhibitory concentration: > 50000 nM
Compound 4 was reported as a limit; the forecaster's own chance of this, stated with the estimate: 40%; at least 2.5-fold (0.39 log units) between middle value and limit.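

In this assay compound 4 gives > 50000 nM, which is a limit of the assay. Compound 2 also stands at a limit, so no step can be read between compound 2 and compound 4. From the compounds shown here alone, how 4-methylphenyl and 1-methyl-1H-pyrrol-3-yl on this carbonyl carbon compare in potency remains open.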